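The compounds below may be only part of what the source reports. "The series", "measured", "known", "first", "only" and "open" are said of these compounds alone.

The series gathers aryl sulfonamides built on the shared core of compound 1, `O=S(=O)(Nc1ccc(-c2nc3ccccc3o2)cc1)c1ccc(Cl)c(C(F)(F)F)c1`, and measures them in an assay on cells for inhibition of HSP60/HSP10 (Homo sapiens), with a stated time of 60 min; a higher number here means a weaker inhibitor, a lower number a stronger inhibitor. Compound 1 gives 12000 nM in this assay. Compound 2, `Cc1ccccc1S(=O)(=O)Nc1ccc2oc(-c3ccccc3)nc2c1`, reaches only the detection limit of the assay, and its value of > 100000 nM is a limit rather than a number. Compound 3, `O=S(=O)(Nc1ccc(-c2nc3ccccc3o2)cc1)c1ccccc1F`, likewise returns > 100000 nM, which is again a limit and not a number. Thus two of the three values sit at the same boundary: the limit of > 100000 nM in this assay, at which 2 of the 3 values shown sit.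

Compound 2 therefore stands at the weak end of the numbers shown; nothing places it relative to compound 3, since both are limits, while compound 1 alone gives a measured concentration.

The step considered here leads from compound 2 to compound 4, `CS(=O)(=O)Nc1ccc2oc(-c3ccccc3)nc2c1`, which is not yet measured in this assay. The change is methyl in place of 2-methylphenyl on a sulfonyl sulfur. Among the compounds with values here, no measured step between related compounds is available to calibrate it, so the expectation rests on the standing of compound 2 alone. With compound 2 already at the limit, the step is expected to be a step that the limit leaves unreadable from compound 2 to compound 4, that is, no resolvable change beyond the scatter, with compound 4 most likely also reported as a limit. Compound 4 is estimated at 150000 nM, within a range from 40000 nM to 600000 nM.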

Compound 4, half-maximal inhibitory concentration: > 100000 nM
Compound 4: no number, only a limit; the forecaster's own chance of this, stated with the estimate: 85%; the middle value lies beyond the limit too.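

In this assay compound 4 returns > 100000 nM, which is a limit and not a number. Compound 2 also stands at a limit, so no step between compound 2 and compound 4 can be read, because both lie at the same boundary: the limit of > 100000 nM in this assay, at which 3 of the 4 values shown sit.

On these data alone, whether methyl or 2-methylphenyl on the sulfonyl sulfur gives the stronger inhibitor remains open.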